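The source may report more compounds than this note shows. Statements on the series, on what has been measured and on what is new or still open speak of the compounds shown alone.

Compound 1 `CCCOc1ccc(NC(=O)CSc2nnc(Cc3nn(C)c(=O)c4ccccc34)n2C)cc1` shows the shared core of this set. In an assay on isolated protein (Mus musculus) for inhibition of IL15-IL15 receptor (Homo sapiens), read by resazurin assay, with stated times of 30 min and 2.5 days (on this read-out higher numbers stand for weaker inhibition and lower numbers for stronger inhibition), compound 1 gives only a limit, > 30000 nM, and not a number. Among the values shown, compound 1 sits at the limit of > 30000 nM in this assay, at which 1 of the 3 values shown sits. Compound 2 `Cn1c(Cc2nn(C)c(=O)c3ccccc23)nnc1SCCCCCCCCCCC(=O)Nc1ccccc1Cl` carries a long chain to the amide and in this assay gives 15000 nM. Compound 3 `Cn1c(Cc2nn(C)c(=O)c3ccccc23)nnc1SCCCCCCCCCCC(=O)Nc1ccc(Cl)cc1` gives 20000 nM. Among the measured compounds shown here, the only step between measured compounds, a 1.3-fold higher number from compound 2 to compound 3 (0.12 log units; within the scatter), stays within the scatter. Compound 4 `Cn1c(Cc2nn(C)c(=O)c3ccccc23)nnc1SCC(=O)Nc1ccc(Br)cc1Br` is not yet measured; it differs from compound 1 by 2,4-dibromophenyl in place of 4-propoxyphenyl on an amide-type nitrogen. The step from compound 2 to compound 3 also exchanges one chlorophenyl for another on the amide-type nitrogen and was within the scatter, but it sits on a chain of another length and on numbers rather than a limit, so it bears on the present change only loosely. Compound 1 offers only a limit, so no direction follows from it. Compound 4 is therefore expected to remain near that limit, with the step of a number no higher from compound 1 to compound 4 (the limit leaves the size open) estimated as none beyond the scatter. Compound 4 is estimated at 30000 nM, within 8000 nM to 120000 nM.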

Compound 4, half-maximal inhibitory concentration: > 30000 nM
Compound 4: a limit, no number; the forecaster's own chance of this, stated with the estimate: 50%; the middle value lies on the limit itself.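

Compound 1 and compound 4 both give only a limit in this assay, so the step between them cannot be read: the limit of > 30000 nM in this assay, at which 2 of the 4 values shown sit. The compounds shown leave open how 2,4-dibromophenyl and 4-propoxyphenyl on an amide-type nitrogen compare on the core of compound 1.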